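Adding a Third Methoxy Group to a Benzylamine Side Chain

This account rests on a few compounds, and the source may have more. Where it says the series, first, only, none or still open, it means among the compounds named here.

Compound 1 `Nc1cc(N)c2nc(-c3ccccc3)c(NCc3ccc(Cl)c(Cl)c3)nc2c1` and compound 2 `COc1ccc(CNc2nc3cc(N)cc(N)c3nc2-c2ccccc2)cc1OC` share one core and differ only in the aromatic group carried on the chain attached to the ring nitrogen. In a functional assay on KM12 cells (Homo sapiens) for inhibition, read by sulforhodamine B assay, with a stated time of 48 h (a lower number here means a stronger inhibitor of growth, a higher number a weaker inhibitor of growth), compound 1 gives 21400 nM, while compound 2 gives 30900 nM. The step of a 1.4-fold higher number from compound 1 to compound 2 (0.16 log units; within the scatter) shows that swapping the two chlorines for two methoxy groups keeps the result within the scatter of the measurement. Compound 2 thus holds the highest of the two numbers, but its gap to compound 1 is within that scatter, so the two compounds cannot be told apart here.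

Compound 3 `COc1cc(CNc2nc3cc(N)cc(N)c3nc2-c2ccccc2)cc(OC)c1OC` differs from compound 2 by methoxy in place of hydrogen on an aromatic carbon. For the measured compounds named here, the only measured step that touches this part of the molecule is the small one from compound 1 to compound 2, so for compound 3 the expected step is a 1.0-fold lower number from compound 2 to compound 3 (0.01 log units; within the scatter), with no direction beyond the scatter. Compound 3 is therefore estimated at 30000 nM, ranging from 12000 nM to 75000 nM.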

Compound 3, concentration for total growth inhibition: 10200 nM
Compound 3: the middle estimate sits 2.9-fold (0.47 log units) above what was measured; measured number below the stated range.
By their numbers in this assay, from the lowest: compound 3; then compounds 1 and 2 (each within the scatter of the next).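

In this assay the added methoxy group gives a 3.0-fold lower number from compound 2 to compound 3 (0.48 log units; beyond the scatter) and this modest step lies beyond the scatter. The position on the aromatic ring of the side chain that carries this new group therefore matters for the read-out, at least for this change on compound 2. The earlier swap of two chlorines for two methoxy groups did not show this, since that step stayed within the scatter and could not be told apart from repeat variation. No measurement here bears on why the added methoxy group lowers the number.

Still open, on these data alone, is whether the step belongs to methoxy itself or would also appear with a hydroxy group, a fluorine atom or a longer ethoxy chain at the same place. Also open, as far as these compounds go, is whether a third group at this place would have the same effect on the dichlorinated side chain of compound 1.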